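Urea series: cytotoxicity notes toward compound 4

The compounds below may be only part of what the source reports. "The series", "measured", "known", "first", "only" and "open" are said of these compounds alone.

Compound 1 `COc1ccc(NC(=O)Nc2cc(C)nc3ccccc23)cc1` is the reference point of the set. In an ADME assay on BJ cells (Homo sapiens) for cytotoxicity, with a stated time of 72 h (a higher number here means that more compound is needed for the effect, a lower number that less compound is needed), compound 1 gives > 25000 nM, which is a limit of the assay and not a number. Compound 2 `Cc1ccc(NC(=O)Nc2cc(C)nc3ccccc23)cc1` carries methyl in place of methoxy on an aromatic carbon. In this assay compound 2 gives > 25000 nM, again a limit. Compound 3 `Cc1cc(NC(=O)Nc2ccc(F)cc2)c2ccccc2n1` carries fluoro in place of methoxy on an aromatic carbon relative to compound 1. In this assay compound 3 gives > 25000 nM, also a limit rather than a number.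

Compound 3 therefore stands exactly where the other two measured compounds stand, at the limit of > 25000 nM in this assay, at which 3 of the 3 values shown sit. None of the steps among them can be sized: a step that the two limits leave unreadable from compound 1 to compound 2, a step that the two limits leave unreadable from compound 1 to compound 3 and a step that the two limits leave unreadable from compound 2 to compound 3 are all unreadable because the limit of > 25000 nM in this assay, at which 3 of the 3 values shown sit, caps every value.

Compound 4 `COC(=O)c1ccc(NC(=O)Nc2cc(C)nc3ccccc23)cc1` is not yet measured. The change from compound 3 is methoxycarbonyl in place of fluoro on an aromatic carbon. The three measured steps all exchange the substituent at this place and none of them shows a readable movement in this assay. The expected step is a number no higher from compound 3 to compound 4 (the limit leaves the size open), none beyond the scatter. Compound 4 is estimated at 25000 nM, with a range from 12000 nM to 100000 nM, most probably reported once more as a limit.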

Compound 4, half-maximal effective concentration: 21000 nM
Beside the measured number, compound 4's estimate is 1.2-fold (0.08 log units) above it; the range from low to high includes it.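

In this assay compound 4 gives 21000 nM, the only number among the four values, so methoxycarbonyl on this aromatic carbon, para to a large group, is the one substituent shown here that brings a readout inside the measurable range. Against the earlier compounds the change reads as an at least 1.1-fold lower number from compound 3 to compound 4 (0.07 log units; that floor lies within the scatter), as an at least 1.1-fold lower number from compound 2 to compound 4 (0.07 log units; that floor lies within the scatter) and as an at least 1.1-fold lower number from compound 1 to compound 4 (0.07 log units; that floor lies within the scatter), so the position gives no sign of a change beyond the scatter, even with a substituent of more heavy atoms and with hydrogen-bond acceptors. Each of these steps has only a floor and no full size because the other compounds remain capped: the limit of > 25000 nM in this assay, at which 3 of the 4 values shown sit.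

From the compounds shown here alone, whether a carboxylic acid or an amine at this same place would give a number that differs from that of compound 4 beyond the scatter remains open. Also open, going by these compounds, is how far the true values of compound 1, compound 2 and compound 3 lie from that of compound 4, so no order can be set among the four compounds.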